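Swapping the aryl end of a dienone series

This account rests on a few compounds, and the source may have more. Where it says the series, first, only, none or still open, it means among the compounds named here.

Measured so far:
compound 1, `O=C(/C=C/c1ccc(Oc2ncnc3ccc(Cl)cc23)cc1)/C=C/c1c(Cl)cccc1Cl` — 67.5%
compound 2, `O=C(/C=C/c1ccc(Oc2ncnc3ccc(Cl)cc23)cc1)/C=C/c1ccc(Cl)c([N+](=O)[O-])c1` — 56.3%

In a functional assay on PC-3 cells (Homo sapiens) for inhibition, read by MTT assay, with a stated time of 72 h, tested at 10 uM (on this read-out higher numbers stand for more inhibition of growth at the one concentration tested and lower numbers for less inhibition of growth), compound 1 gives 67.5% and compound 2 gives 56.3%, so compound 2 holds the lower of the two numbers seen. Within the data shown here, the one comparison available is a number 11.2 percentage points lower from compound 1 to compound 2 (beyond the scatter), which exchanges a dichlorophenyl for a chloro-nitrophenyl on the outer end of the dienone.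

The next compound, compound 3 with the structure `O=C(/C=C/c1ccc(Oc2ncnc3ccc(Cl)cc23)cc1)/C=C/c1cccc(Cl)c1Cl`, reverses that kind of exchange: 2,3-dichlorophenyl in place of 4-chloro-3-nitrophenyl on a double-bonded chain carbon bound to a double-bonded chain carbon. Among the measured compounds shown here, only the step from compound 1 to compound 2 bears on it, and that step was modest, so returning from a nitro-bearing ring to a ring carrying two chlorines would be expected to recover part of what was lost, though the new chlorine pattern differs from that of compound 1, and no measured pair tells how much that matters.

Compound 3 is therefore estimated at 63% in this assay, within a range of 50% to 76%, which means an expected step of a number 6.7 percentage points higher from compound 2 to compound 3 (within the scatter) that may well stay inside the usual scatter.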

Compound 3, percent growth inhibition at one concentration: 67.4%
Estimate against measurement, compound 3: 4.4 percentage points below; low and high end bracket the measured number.
By their numbers in this assay, from the lowest: compound 2; then compounds 3 and 1 (each within the scatter of the next).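

In this assay, 2,3-dichlorophenyl in place of 4-chloro-3-nitrophenyl on a double-bonded chain carbon bound to a double-bonded chain carbon gives a number 11.1 percentage points higher from compound 2 to compound 3 (beyond the scatter) and so runs opposite to the earlier step, which had shown only one ring exchange, and in one direction. The exchange of 2,6-dichlorophenyl for 2,3-dichlorophenyl at the same place gives a number 0.1 percentage points lower from compound 1 to compound 3 (within the scatter), so these two chlorine patterns cannot be told apart on this read-out, and among the three compounds only the 4-chloro-3-nitrophenyl ring of compound 2 stands apart from the others. No measurement among those shown speaks to why this ring gives a different number from the two dichlorophenyl rings.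

Compound 2 is the only one of the three that carries either a nitro group or a chlorine at its 4-position, so the compounds shown cannot separate the part played by the nitro group from that of the chlorine pattern. They also leave open how this end of the molecule would respond to a ring carrying a methoxy group, an amine or a carboxylic acid, or to a single chlorine in place of two.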